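The source may report more compounds than this note shows. Statements on the series, on what has been measured and on what is new or still open speak of the compounds shown alone.

Measured so far in a functional assay on HepG2 cells (Homo sapiens) for cytotoxicity, with a stated time of 24 h; on this read-out higher numbers stand for weaker inhibition and lower numbers for stronger inhibition:
compound 1, `O=C(N/N=C/c1cc(I)cc(I)c1O)c1ccc(I)cc1`, 31800 nM
compound 2, `O=C(N/N=C/c1cc(I)cc(I)c1O)c1ccc(C(F)(F)F)cc1`, 11700 nM
compound 3, `O=C(N/N=C/c1cc(I)c(O)c(I)c1)c1ccc(I)cc1`, > 50000 nM

Compound 1 and compound 2 share a core and differ by trifluoromethyl in place of iodo on an aromatic carbon. In this assay that change gave a 2.7-fold lower number from compound 1 to compound 2 (0.43 log units; beyond the scatter). Compound 3 reaches only a limit of this assay, > 50000 nM. That value is the limit of > 50000 nM in this assay, at which 1 of the 3 values shown sits. How the core of compound 3 differs from the core of compound 1 is not broken down here.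

Compound 4, `O=C(N/N=C/c1cc(I)c(O)c(I)c1)c1ccc(C(F)(F)F)cc1`, has not yet been measured in this assay. It differs from compound 3 by trifluoromethyl in place of iodo on an aromatic carbon, the same kind of change as seen between compound 1 and compound 2. The step expected here, an at least 1.2-fold lower number from compound 3 to compound 4 (0.09 log units; that floor lies within the scatter), rests on the measured step of a 2.7-fold lower number from compound 1 to compound 2 (0.43 log units; beyond the scatter), while compound 3 gives only a limit, so the starting point is uncertain. Compound 4 is therefore estimated at 40000 nM, expected to fall between 15000 nM and 120000 nM, and the assay may again report only a limit.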

Compound 4, half-maximal inhibitory concentration: 57400 nM
The estimate for compound 4 lay 1.4-fold (0.16 log units) below the measured number; the measured number falls inside the stated range.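

No step from compound 3 to compound 4 can be read, because compound 3 stands only at a limit: the limit of > 50000 nM in this assay, at which 1 of the 4 values shown sits.

On these data alone, whether trifluoromethyl in place of iodo shifts the number on the core of compound 3 as it does on the core of compound 1 stays open.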